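The source may hold more compounds than are shown below. What is called first, only, known or untested is meant among the compounds shown, and "the series" means these compounds.

Compound 1 `C[Se]c1nc(N)c2ccccc2n1` and compound 2 `Nc1nc([SeH])nc2ccccc12` share one core and were both tested in a functional assay on HTB-54 cells (Homo sapiens) for cytotoxicity, read by MTT assay, with a stated time of 72 h; on this read-out higher numbers stand for weaker inhibition of growth and lower numbers for stronger inhibition of growth. In that assay compound 1 gives 18000 nM, and compound 2 gives 40 nM, so compound 1 stands at the higher of the two numbers, the weaker inhibitor of growth. For the measured compounds named here, the only step between measured compounds, a 450-fold lower number from compound 1 to compound 2 (2.65 log units; beyond the scatter), came from hydrogen in place of methyl on a selenium. Compound 3 `C[Se]c1nc([Se]C)c2ccccc2n1` differs from compound 1 elsewhere: a group of 2 heavy atoms (1 carbon, 1 selenium; no ring) in place of one nitrogen atom, on an aromatic carbon. Going by the values given here, no measured step touches the amino group, so the step from compound 1 to compound 2 does not show what this change should do in this assay. With nothing to lean on, the expectation is a number near that of compound 1, with wide uncertainty. For compound 3 the estimate in this assay is 20000 nM, between 3000 nM and 120000 nM, meaning an expected step of a 1.1-fold higher number from compound 1 to compound 3 (0.05 log units; within the scatter).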

Compound 3, concentration for 50% growth inhibition: 26600 nM
Compound 3: middle estimate off by 1.3-fold (0.12 log units), on the low side; measured number inside the range.
By their numbers in this assay, from the lowest: compound 2; then compounds 1 and 3 (each within the scatter of the next).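

Replacing the amino group, on an aromatic carbon, with a group of 2 heavy atoms (1 carbon, 1 selenium; no ring) gives a 1.5-fold higher number from compound 1 to compound 3 (0.17 log units; within the scatter) in this assay. For the compounds shown here, the earlier step touched only the methyl on a selenium, so this is the first reading at the amino position, and it shows that losing the amino group, with its hydrogen-bond donor and acceptor, moves the number no further than the usual scatter. Nothing measured here speaks to what lies behind this result.

Still open, as far as these compounds go, is whether other groups at this position, such as a methoxy group, a dimethylamino group or a longer chain, would also leave the number within the scatter. Also open, from the compounds shown here alone, is whether hydrogen in place of methyl on a selenium would bring a large step in compound 3, as it does in the pair already compared.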